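The source may hold more compounds than are shown below. What is called first, only, known or untested is meant among the compounds shown, and "the series" means these compounds.

In an ADME assay on a cell-free system (plasma, Rattus norvegicus, strain Sprague-Dawley) for metabolic stability, read by LC-MS, with a stated time of 120 min, tested at 1 uM (on this read-out higher numbers stand for a more stable compound and lower numbers for a less stable compound), compound 1 `CC#CCn1c(N2CCC[C@@H](N)C2)cc(=O)n(Cc2ccc(Cl)c(C(=O)O)c2)c1=O` gives 27.8% and compound 2 `CC#CCn1c(N2CCC[C@@H](N)C2)cc(=O)n(Cc2ccc(F)c(C(=O)O)c2)c1=O` gives 22.5%. Compound 2 therefore stands level with compound 1 within the usual scatter, and these two numbers are the only ones available so far.

Compound 3 `CC#CCn1c(N2CCC[C@@H](N)C2)cc(=O)n(Cc2ccc(Br)c(C(=O)O)c2)c1=O` has not yet been measured. It differs from compound 2 by one halogen (bromo in place of fluoro on an aromatic carbon), with bromo in place of fluoro on an aromatic carbon.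

Within the data shown here, only one measured step bears on this change: fluoro in place of chloro on an aromatic carbon, a number 5.3 percentage points lower from compound 1 to compound 2 (within the scatter). Among the measured compounds shown here, it is a single step and includes no bromo compound, so it is a thin guide. On that evidence, no step beyond the scatter is expected in this assay. The expected step is a number 3.5 percentage points higher from compound 2 to compound 3 (within the scatter). Compound 3 is estimated at 26%, with an expected range from 14% to 39%.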

Compound 3, percent of the compound remaining: 19.2%
Beside the measured number, compound 3's estimate is 6.8 percentage points above it; measured number inside the range.
By their numbers in this assay, from the lowest: compounds 3, 2 and 1 (each within the scatter of the next).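

On the aromatic carbon ortho to a carboxy group, fluoro, chloro and bromo can now be compared in this assay as three members of one halogen series. Bromo in place of fluoro brings a number 3.3 percentage points lower from compound 2 to compound 3 (within the scatter) and bromo in place of chloro brings a number 8.6 percentage points lower from compound 1 to compound 3 (within the scatter) so neither new step separates bromo from the other two halogens, and across these three compounds the choice of halogen at this place makes no readable difference to how much compound remains. Nothing at hand explains these numbers.

Still open, on these data alone, is whether a group that is not a halogen at this place, such as methyl, methoxy or a nitrile, would give a step beyond the scatter. Plain hydrogen at this place is equally open, and it would show whether having any halogen there matters at all.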